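This account rests on a few compounds, and the source may have more. Where it says the series, first, only, none or still open, it means among the compounds named here.

Measured so far in a functional assay on Ehrlich cells (Mus musculus) for cytotoxicity, read by trypan blue exclusion, with a stated time of 2 h, tested at 100 ug/mL; on this read-out higher numbers stand for a stronger effect at the one concentration tested and lower numbers for a weaker effect:
- compound 1 `N#CC1=C(N)N(c2ccc(S(N)(=O)=O)cc2)C2=C(C(=O)CCC2)C1c1ccc(Cl)cc1Cl` gives 95%
- compound 2 `Cc1ccc(C(=O)NC2=C(C#N)C(c3ccc(Cl)cc3Cl)C3=C(CCCC3=O)N2c2ccc(S(N)(=O)=O)cc2)cc1` gives 40%
- compound 3 `N#CC1=C(NC(=O)c2ccc([N+](=O)[O-])cc2)N(c2ccc(S(N)(=O)=O)cc2)C2=C(C(=O)CCC2)C1c1ccc(Cl)cc1Cl` gives 70%

Compound 1 stands highest of the three numbers. Its nearest neighbour is compound 3, reached by a number 25 percentage points lower from compound 1 to compound 3 (beyond the scatter), and its furthest is compound 2, reached by a number 55 percentage points lower from compound 1 to compound 2 (beyond the scatter); between those two acylated compounds the change of an aromatic substituent gives a number 30 percentage points higher from compound 2 to compound 3 (beyond the scatter). Every measured step therefore concerns the amine nitrogen or the acyl group that sits on it, and all steps away from compound 1 lowered the read-out.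

Compound 4 `NC(=O)C1=C(N)N(c2ccc(S(N)(=O)=O)cc2)C2=C(C(=O)CCC2)C1c1ccc(Cl)cc1Cl` differs from compound 1 in another place: carbamoyl in place of cyano on a double-bonded ring carbon. Among the compounds with values here, none of the measured steps touches the cyano group, so nothing here speaks directly to this change. Within the data shown here, compound 1 being the top of the series, the room upward is small, and the only precedent is that changes to compound 1 lowered the number. A step of a number 15 percentage points lower from compound 1 to compound 4 (beyond the scatter) is therefore expected, small and possibly within the scatter. Compound 4 is estimated at 80%, with a range from 55% to 100%.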

Compound 4, a percentage reported as activity, at one concentration (the size of the read-out at that concentration, not a potency): 45%
For compound 4 the middle estimate is 35 percentage points above the measured one, outside the stated range (below it).
By their numbers in this assay, from the lowest: compounds 2 and 4 (each within the scatter of the next); then compound 3; then compound 1.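

Carbamoyl in place of cyano gives a number 50 percentage points lower from compound 1 to compound 4 (beyond the scatter) in this assay, so the read-out of compound 1 depends on more than the amine nitrogen and the acyl group placed on it. The double-bonded ring carbon, next to the ring atom that bears a 2,4-dichlorophenyl group and next to the ring atom that bears an amino group, is thus a place where exchanging one group for another can cost a large part of the read-out. No available evidence explains this loss.

As far as these compounds go, whether a carboxylic acid, a methyl ester or a plain hydrogen on this carbon would retain the read-out of compound 1 remains open. Also open, from the compounds shown here alone, is how acylation of the amine nitrogen would act with carbamoyl rather than cyano on this carbon.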